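Thiophene to Pyridine on a Sulfur in Two Related Series

This account rests on a few compounds, and the source may have more. Where it says the series, first, only, none or still open, it means among the compounds named here.

Measured so far:
compound 1 `C=C1CC[C@@H]2[C@](C)(CO)[C@H](O)CC[C@@]2(C)[C@@H]1CC(Sc1cccs1)C1=CCOC1=O` — 15000 nM
compound 2 `C=C1CC[C@@H]2[C@](C)(CO)[C@H](O)CC[C@@]2(C)[C@@H]1CC(Sc1ccccn1)C1=CCOC1=O` — 18000 nM
compound 3 `C=C1CC[C@@H]2[C@](C)(CO)[C@H](O)CC[C@@]2(C)[C@@H]1C/C=C1/C(=O)OC[C@H]1OC(=O)CCCSc1cccs1` — 16000 nM

In a functional assay on PC-3 cells (Homo sapiens) for inhibition, read by MTT assay, with a stated time of 48 h (a higher number here means a weaker inhibitor, a lower number a stronger inhibitor), compound 1 gives 15000 nM, while compound 2 gives 18000 nM. The two differ at a single spot: pyridin-2-yl in place of thiophen-2-yl on a sulfur. This change gave a 1.2-fold higher number from compound 1 to compound 2 (0.08 log units; within the scatter), so the two values cannot be told apart by this assay.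

Compound 3 belongs to a different core; how it differs from the core of compound 1 is not broken down here. In this assay compound 3 gives 16000 nM, and all three measured numbers lie within the scatter of one another.

Compound 4 `C=C1CC[C@@H]2[C@](C)(CO)[C@H](O)CC[C@@]2(C)[C@@H]1C/C=C1/C(=O)OC[C@H]1OC(=O)CCCSc1ccccn1` has not yet been measured. It stands to compound 3 exactly as compound 2 stands to compound 1: pyridin-2-yl in place of thiophen-2-yl on a sulfur. The place of the change is described in the same words in both pairs, so this is the same change on a second core. Among the compounds with values here, the only evidence for its effect is the step from compound 1 to compound 2, which is expected to carry over, and because a 1.2-fold higher number from compound 1 to compound 2 (0.08 log units; within the scatter) was within the scatter, the expected step is a 1.2-fold higher number from compound 3 to compound 4 (0.07 log units; within the scatter). Compound 4 is therefore estimated at 19000 nM in this assay, with the expected range running from 9000 nM to 40000 nM.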

Compound 4, half-maximal inhibitory concentration: 14000 nM
Beside the measured number, compound 4's estimate is 1.4-fold (0.13 log units) above it; measured number inside the range.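

In this assay, putting pyridin-2-yl in place of thiophen-2-yl on the second core gives a 1.1-fold lower number from compound 3 to compound 4 (0.06 log units; within the scatter), a step too small to count as a real change. Set side by side, the steps on the two cores do not differ: the same change on two cores in this assay, a 1.2-fold higher number (0.08 log units; within the scatter) from compound 1 to compound 2 and a 1.1-fold lower number (0.06 log units; within the scatter) from compound 3 to compound 4, 1.4-fold (0.14 log units) apart, within the scatter of two such steps. This shows that the swap produces no step beyond the scatter on either of these two cores in this one assay, but it does not show that the same would hold on a third core, and with no clear effect on either core, there is no real shift here that could be said to carry over.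

All four compounds hold an aromatic ring on the sulfur, leaving open what a saturated group there, such as a plain butyl chain or a chain ending in an amine, would do. Also open, going by these compounds, is whether a carboxylic acid added to the thiophene or pyridine ring would move the number beyond the scatter on either core.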